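A few compounds are considered here, and "the series" means these few. Any claim that something is new, unique, unknown or untested is made for them only; others in the source may bear on it.

Of the compounds shown here, three that share one core have been tested in a functional assay on MCF7 cells (Homo sapiens) for antiproliferative activity, read by MTT assay, with a stated time of 72 h; on this read-out lower numbers stand for stronger inhibition and higher numbers for weaker inhibition. Compound 1 `O=C(COc1ccc(C(=O)/C=C/c2ccccc2Cl)cc1)N[C@H]1CCOC1=O` gives 17400 nM. Compound 2 `COc1ccccc1/C=C/C(=O)c1ccc(OCC(=O)N[C@H]2CCOC2=O)cc1` reaches only the limit of this assay, > 64000 nM, so no number is known for it. Compound 3 `O=C(COc1ccc(C(=O)/C=C/c2cccc([N+](=O)[O-])c2)cc1)N[C@H]1CCOC1=O` also sits at that limit, > 64000 nM, which is likewise not a number. Compound 3 thus stands at the weak end of what has been measured, at the limit of > 64000 nM in this assay, at which 2 of the 3 values shown sit, while only compound 1 yields a number. The measured steps show an at least 3.6-fold higher number from compound 1 to compound 2 (0.56 log units; beyond the scatter) and an at least 3.6-fold higher number from compound 1 to compound 3 (0.56 log units; beyond the scatter), whereas a step that the two limits leave unreadable from compound 2 to compound 3.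

Compound 4 `O=C(COc1ccc(C(=O)/C=C/c2cccc(F)c2)cc1)N[C@H]1CCOC1=O` has not yet been measured. It differs from compound 3 in one place: fluoro in place of nitro on an aromatic carbon. Compound 4 therefore carries a halogen on its phenyl group, as compound 1 does, though in compound 4 it is fluoro on a 3-fluorophenyl group and in compound 1 chloro on a 2-chlorophenyl group. The step that bears on this change is an at least 3.6-fold higher number from compound 1 to compound 3 (0.56 log units; beyond the scatter), which replaced a halogen-bearing phenyl with a nitro-bearing one and weakened the inhibition; going back from nitro to a halogen may be expected to reverse part of that. Compound 4 is thus expected to give about 30000 nM, with a range from 10000 nM to 90000 nM. For compound 4 the expected step is an at least 2.1-fold lower number from compound 3 to compound 4 (0.32 log units; beyond the scatter).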

Compound 4, half-maximal inhibitory concentration: > 64000 nM
Compound 4: a limit, no number; the forecaster's own chance of this, stated with the estimate: 35%; at least 2.1-fold (0.32 log units) between middle value and limit.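

Fluoro on this aromatic carbon, meta to a large group, leaves the compound at the limit of this assay just as nitro does, so a halogen on this phenyl group is not enough on its own to give a readable number: the limit of > 64000 nM in this assay, at which 3 of the 4 values shown sit.

Going by these compounds alone, changing 2-chlorophenyl to 3-fluorophenyl gives an at least 3.6-fold higher number from compound 1 to compound 4 (0.56 log units; beyond the scatter), so compound 1 remains the only compound here with a number and the only one separated from the others by a readable step. The steps among compound 2, compound 3 and compound 4 have a limit at both ends and cannot be read, so nothing can be said about any order among these three.

The change from compound 1 to compound 4 alters both the halogen and where it sits on the ring, and the compounds shown do not separate these two changes, which chloro in place of fluoro at this same ring carbon would begin to do. Going by these compounds, it also remains open whether an amine or a methyl group on this carbon would bring a number within reach of this assay.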